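This account rests on a few compounds, and the source may have more. Where it says the series, first, only, none or still open, it means among the compounds named here.

Measured in a functional assay on HCT-116 cells (Homo sapiens) for antiproliferative activity, with a stated time of 72 h; on this read-out lower numbers stand for stronger inhibition and higher numbers for weaker inhibition:
Compound 1 `CC(=O)Oc1cccc(/C=C/c2nc3ccccc3c(=O)[nH]2)c1`: 15300 nM
Compound 2 `CC(=O)Oc1ccc(/C=C/c2nc3ccccc3c(=O)[nH]2)c(OC(C)=O)c1`: > 25000 nM, a limit, not a number
Compound 3 `COc1ccccc1/C=C/c1nc(Nc2ccc(O)cc2)c2ccccc2n1`: > 25000 nM, a limit, not a number

For the measured compounds named here, compound 1 gives 15300 nM, the only true number. The remaining values stand at the limit of > 25000 nM in this assay, at which 2 of the 3 values shown sit.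

Compound 4 `COc1cccc(/C=C/c2nc3ccccc3c(=O)[nH]2)c1` differs from compound 1 in one place: methyl in place of acetyl on an oxygen on an aromatic ring. This is acetoxy to methoxy, with methyl in place of acetyl on an oxygen on an aromatic ring. Going by the values given here, no measured pair shows this change, so no size can be read from the data. In this assay, no step beyond the scatter is expected, and no direction is favoured. The expected change is a 1.0-fold higher number from compound 1 to compound 4 (0.02 log units; within the scatter). Compound 4 is estimated at 16000 nM, with an expected range of 6000 nM to 25000 nM.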

Compound 4, half-maximal inhibitory concentration: > 25000 nM
Compound 4 was reported as a limit (the forecaster's own chance of this, stated with the estimate: 30%); at least 1.5-fold (0.19 log units) between middle value and limit.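

In this assay, methyl in place of acetyl on an oxygen on an aromatic ring gives an at least 1.6-fold higher number from compound 1 to compound 4 (0.21 log units; that floor lies within the scatter). The value of compound 4 is a limit and not a number, so the step is only a floor and its true size cannot be read. Compound 1 remains the only compound in the series with a true number: the limit of > 25000 nM in this assay, at which 3 of the 4 values shown sit.

Open, going by these compounds, is how an amine or a longer acyl chain in place of the acetyl would read out on the same core. With a single true number, no trend can yet be drawn for this position.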